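The compounds below may be only part of what the source reports. "The series", "measured", "known", "first", "only" and "open" are said of these compounds alone.

Working notes on the series. Compound 1 `C=CCc1cc(O)c(O)c(CN2CCC(CO)CC2)c1` gives 32.3% in a functional assay on MCF7 cells (Homo sapiens) for inhibition, read by MTT assay, with a stated time of 72 h, tested at 50 uM (a lower number here means less inhibition of growth, a higher number more inhibition of growth at the concentration tested), the largest of the three numbers recorded. Compound 3 `C=CCc1ccc(OCc2cn(-c3ccc(Br)cc3)nn2)c(O)c1` gives 29.1% in this assay, a gap within the scatter, so no order between compound 1 and compound 3 is claimed. Compound 2 `C#CCOc1ccc(CC=C)cc1O` gives 15.8% in this assay, a gap beyond the scatter.

Compound 4 `C=CCc1cc(O)c(O)c(CN2CCC(C)CC2)c1` differs from compound 1 in one place: hydrogen in place of hydroxy on a saturated chain carbon bound to a saturated ring carbon. Among the compounds with values here, no pair of measured compounds shows this change, so no measured step guides it. The expected step is a number 4.3 percentage points lower from compound 1 to compound 4 (within the scatter), a small shift downward that stays within the scatter. For compound 4 the estimate in this assay is 28%, with a range from 15% to 42%.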

Compound 4, percent growth inhibition at one concentration: 54.2%
Compound 4: middle estimate off by 26.2 percentage points, on the low side, outside the stated range (above it).
By their numbers in this assay, from the lowest: compound 2; then compounds 3 and 1 (each within the scatter of the next); then compound 4.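

Hydrogen in place of hydroxy on a saturated chain carbon bound to a saturated ring carbon gives a number 21.9 percentage points higher from compound 1 to compound 4 (beyond the scatter) in this assay. This first single-place step in the series shows that growth inhibition at the concentration tested is sensitive to this position, and that the hydroxymethyl group of compound 1 is not required for it. Nothing at hand accounts for the size of this step.

The compounds shown leave open how an ethyl group, an amine or a carboxylic acid at this place would compare with methyl. Going by these compounds, whether the step holds on a different core also stays open.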